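This account rests on a few compounds, and the source may have more. Where it says the series, first, only, none or still open, it means among the compounds named here.

In a physicochemical assay for solubility, in phosphate buffer, with a stated time of 18 h, at pH 7.4 (a higher number here means a more soluble compound, a lower number a less soluble compound), compound 1 `COc1cc2ncnc(-n3nc(-c4ccccn4)nc3N)c2cc1N` gives 3000 nM and compound 2 `COc1cc2ncnc(-n3nc(-c4ccccn4)nc3N)c2cc1OCCCNC(=O)OC(C)(C)C` gives 2000 nM, so the two numbers lie within the scatter of each other. Compound 3 `COc1cc2ncnc(-n3nc(-c4ccccn4)nc3N)c2cc1OCCNC(=O)OC(C)(C)C` differs from compound 2 in the chain alone: (tert-butoxycarbonyl)amino in place of ((tert-butoxycarbonyl)amino)methyl on a saturated chain carbon, two bonds along the chain from an oxygen on an aromatic ring. In words, this is (tert-butoxycarbonyl)amino in place of ((tert-butoxycarbonyl)amino)methyl on a saturated chain carbon, two bonds along the chain from an oxygen on an aromatic ring, which turns 3-((tert-butoxycarbonyl)amino)propoxy into 2-((tert-butoxycarbonyl)amino)ethoxy. For the measured compounds named here, no measured step changes the chain length. The nearest evidence is a 1.5-fold lower number from compound 1 to compound 2 (0.18 log units; within the scatter), with 3-((tert-butoxycarbonyl)amino)propoxy in place of amino on an aromatic carbon. Going by the values given here, with that step as the only guide, no shift beyond the scatter is expected in this assay, in either direction. The estimated step is no change at the digits printed from compound 2 to compound 3 (within the scatter). For compound 3 the expected value is 2000 nM, with an estimated range of 1000 nM to 4000 nM.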

Compound 3, solubility: 2000 nM
Compound 3: middle estimate and measured number agree at the digits printed; measured number inside the range.
By their numbers in this assay, from the lowest: compounds 2, 3 and 1 (each within the scatter of the next).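

In this assay, the change from 3-((tert-butoxycarbonyl)amino)propoxy to 2-((tert-butoxycarbonyl)amino)ethoxy gives no change at the digits printed from compound 2 to compound 3 (within the scatter) and is a direct reading of chain length, on a saturated chain carbon, two bonds along the chain from an oxygen on an aromatic ring, which the earlier pair could not give. Replacing amino with the shorter chain gives a 1.5-fold lower number from compound 1 to compound 3 (0.18 log units; within the scatter) and so, like the longer chain, leaves the number within the scatter of compound 1. Nothing measured here bears on the cause of these readings.

The compounds shown leave open whether a longer chain carrying (tert-butoxycarbonyl)amino would also stay within the scatter. They also leave open whether a free amine or a carboxylic acid in place of (tert-butoxycarbonyl)amino would move the number in this assay beyond it.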